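The source may hold more compounds than are shown below. What is called first, only, known or untested is meant among the compounds shown, and "the series" means these compounds.

Compound 1 `COc1ccc(/C=C/C(=O)c2cccc(-c3cccc(F)c3)c2)cc1` gives 740 nM in a functional assay on CNE-2 cells (Homo sapiens) for cytotoxicity, read by sulforhodamine B assay, with a stated time of 48 h; on this read-out lower numbers stand for stronger inhibition and higher numbers for weaker inhibition. Compound 3 `COc1ccc(/C=C/C(=O)c2cccc(-c3cccc(F)c3)c2)cc1OC` gives 770 nM in this assay. Compound 2 `COc1cc(/C=C/C(=O)c2ccc(N)c(-c3ccc(F)cc3)c2)cc(OC)c1OC` gives 4600 nM in this assay.

Compound 1 and compound 3 share a core and differ in one place: hydrogen in place of methoxy on an aromatic carbon. That step, a 1.0-fold lower number from compound 3 to compound 1 (0.02 log units; within the scatter), changed little. Compound 2 stands apart from both; the difference between its core and that of compound 3 is not broken down here, and its value lies well beyond the scatter from either of the other two.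

Compound 4 `COc1ccc(/C=C/C(=O)c2ccc(N)c(-c3ccc(F)cc3)c2)cc1OC` is not yet measured. It differs from compound 2 by the same kind of change as that from compound 3 to compound 1: hydrogen in place of methoxy on an aromatic carbon. The place is not quite the same, since in compound 2 the leaving methoxy is also meta to a methoxy group. Because a 1.0-fold lower number from compound 3 to compound 1 (0.02 log units; within the scatter) lay within the scatter, the step from compound 2 to compound 4 is expected to be of similar size, a 1.0-fold lower number from compound 2 to compound 4 (0.01 log units; within the scatter). Compound 4 is therefore estimated at 4500 nM in this assay, with a likely range from 2000 nM to 10000 nM.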

Compound 4, half-maximal inhibitory concentration: 3510 nM
Compound 4: middle estimate off by 1.3-fold (0.11 log units), on the high side; low and high end bracket the measured number.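

On a second core in this assay, hydrogen in place of methoxy on an aromatic carbon gives a 1.3-fold lower number from compound 2 to compound 4 (0.12 log units; within the scatter). Set beside the step on the first core, the two do not differ: the same change on two cores in this assay, a 1.0-fold lower number (0.02 log units; within the scatter) from compound 3 to compound 1 and a 1.3-fold lower number (0.12 log units; within the scatter) from compound 2 to compound 4, 1.3-fold (0.10 log units) apart, within the scatter of two such steps. For the compounds shown here, this shows that on these two cores the exchange carries over as a step within the scatter, but it rests on only two pairs and does not show that the same would hold on any other core.

The compounds shown leave open how other groups at this place, such as a hydroxyl group, an ethoxy group or a longer alkoxy chain, would compare with methoxy and hydrogen on either core. Also open, going by these compounds, is what an acetamide or a carboxylic acid in place of the amine on the core of compound 4 would give, and whether the exchange of methoxy for hydrogen would then still stay within the scatter.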